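A few compounds are considered here, and "the series" means these few. Any claim that something is new, unique, unknown or untested is made for them only; others in the source may bear on it.

In a functional assay on MCF7 cells (Homo sapiens) for inhibition, read by MTT assay, with a stated time of 48 h (a lower number here means a stronger inhibitor, a higher number a weaker inhibitor), compound 1 `COc1ccc(C(=O)C=CNc2cc(-c3ccccc3)nn2-c2ccccc2)cc1` gives 1290 nM and compound 2 `Fc1ccc(-c2ccnc3c2c(-c2ccccc2)nn3-c2ccccc2)cc1` gives 1570 nM. These two values lie within the usual scatter of each other, so compound 1 stands level with compound 2. Compound 3 `Cc1ccc(C(=O)C=CNc2cc(-c3ccccc3)nn2-c2ccccc2)cc1` keeps the core of compound 1 but has methyl in place of methoxy on an aromatic carbon. Among the measured compounds shown here, no measured pair of compounds shows this change, so no step beyond the scatter is expected in this assay. The estimated step of a 1.2-fold higher number from compound 1 to compound 3 (0.07 log units; within the scatter) is small. For compound 3 the expected value is 1500 nM, with an estimated range of 500 nM to 4500 nM.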

Compound 3, half-maximal inhibitory concentration: 30200 nM
Compound 3: the middle estimate sits 20-fold (1.30 log units) below what was measured; measured number outside the range, above it.
By their numbers in this assay, from the lowest: compounds 1 and 2 (each within the scatter of the next); then compound 3.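

Swapping 4-methoxyphenyl for 4-methylphenyl leaves the rest of compound 1 unchanged, yet in this assay it gives a 23-fold higher number from compound 1 to compound 3 (1.37 log units; beyond the scatter) and so a much weaker inhibitor. This place, para to a large group, is therefore highly sensitive to which small group sits on it, which compound 1 and compound 2 could not show on their own. Nothing measured here explains the size of this step.

From the compounds shown here alone, what remains open is how other groups would fare at this place. An ethoxy group, a hydroxy group or an amine could show whether the oxygen of methoxy is what matters.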